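Aryl sulfone series: chloro to methyl on the sulfonyl ring

This account rests on a few compounds, and the source may have more. Where it says the series, first, only, none or still open, it means among the compounds named here.

The three measured compounds share one core, seen in compound 1 `COc1ccc2ncc(S(=O)(=O)c3ccc(C)cc3)c(N3CCC(C)CC3)c2c1`, compound 2 `CC1CCN(c2c(S(=O)(=O)c3ccc(Cl)cc3)cnc3cc(F)ccc23)CC1` and compound 3 `CC1CCN(c2c(S(=O)(=O)c3ccc(Cl)cc3)cnc3cc(Cl)ccc23)CC1`. In an assay on isolated protein for displacement of a labelled ligand from metabotropic glutamate receptor 5 (Homo sapiens), with a stated time of 60 min, tested at 1 uM (a lower number here means less inhibition, a higher number more inhibition at the concentration tested (going by the name of the read-out)), compound 1 gives 90%. In this assay compound 2 gives 90%, level with compound 1 at the digits printed and, together with it, the lowest of the three numbers; compound 3 gives 91%. For the measured compounds named here, the one step measured in one place, a number 1 percentage points higher from compound 2 to compound 3 (within the scatter), is within the scatter, so the series so far shows no change that can be read.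

Compound 4 `Cc1ccc(S(=O)(=O)c2cnc3cc(F)ccc3c2N2CCC(C)CC2)cc1` is not yet measured. It differs from compound 2 by methyl in place of chloro on an aromatic carbon. Going by the values given here, no measured step changes this group alone; compound 1 carries the methyl and compound 2 the chloro, but they differ in a second place too, so only their two values can be set side by side, and both read the same. Given that and the flat step from compound 2 to compound 3, no change beyond the scatter is expected for this assay, the expected step being a number 1 percentage points lower from compound 2 to compound 4 (within the scatter). Compound 4 is therefore estimated at 89%, between 80% and 96%.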

Compound 4, a percentage reported as inhibition, at one concentration (the size of the read-out at that concentration, not a potency): 88%
For compound 4 the middle estimate is 1 percentage points above the measured one; the range from low to high includes it.
By their numbers in this assay, from the lowest: compounds 4, 1, 2 and 3 (each within the scatter of the next).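

In this assay the change from 4-chlorophenyl to 4-methylphenyl now stands as a step measured in one place (a number 2 percentage points lower from compound 2 to compound 4 (within the scatter)), which compound 1 and compound 2 could not give, as those two differ in a second place as well. On this aromatic carbon, para to a large group, methyl in place of chloro therefore leaves the inhibition at the concentration tested unchanged within the scatter, so far only with the fluoro of compound 2 kept in place. No measurement is at hand that bears on the reason for this flat result.

Going by these compounds, what a carboxylic acid, an amine or a longer chain would do at this position stays open. As the read-out comes from one concentration, any difference in potency among the compounds shown also stays open.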